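Replacing the acetyl(methyl)amino group of compound 2

A few compounds are considered here, and "the series" means these few. Any claim that something is new, unique, unknown or untested is made for them only; others in the source may bear on it.

Measured in a functional assay on the whole organism for antagonist activity, with Mus musculus as the target; a lower number here means that less compound is needed, a higher number that more compound is needed for the effect:
- compound 1 `CC(=O)NCC#CCn1cncc1C`: 66 mg/kg
- compound 2 `CC(=O)N(C)CC#CCn1cncc1C`: 6.6 mg/kg

Of these two, compound 2 has the lower number in this assay, at 6.6 mg/kg, so less of it is needed for the effect. Compound 3 `COC(=O)NCC#CCn1cncc1C` has not yet been measured. It carries (methoxycarbonyl)amino in place of acetyl(methyl)amino on a saturated chain carbon bound to a triple-bonded carbon.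

Going by the values given here, only one measured step bears on this change. It is a 10-fold lower number from compound 1 to compound 2 (1.00 log units; beyond the scatter), and it put methyl in place of hydrogen on an amide-type nitrogen. The group entering compound 3 has hydrogen rather than methyl on that nitrogen, so the change reverses that step in part. Among the compounds with values here, no measured step shows what methoxycarbonyl does in place of acetyl, which leaves the expectation loose. The expected change is a 6.1-fold higher number from compound 2 to compound 3 (0.78 log units; beyond the scatter), most of the way back up that step. For compound 3 the estimated value is 40 mg/kg, with an expected range of 10 mg/kg to 150 mg/kg.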

Compound 3, dose for half-maximal effect: 66 mg/kg
Estimate against measurement, compound 3: 1.7-fold (0.22 log units) below, within the range that was stated.
By their numbers in this assay, from the lowest: compound 2; then compounds 1 and 3 (each within the scatter of the next).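

In this assay, (methoxycarbonyl)amino in place of acetyl(methyl)amino on a saturated chain carbon bound to a triple-bonded carbon gives a 10-fold higher number from compound 2 to compound 3 (1.00 log units; beyond the scatter), so this replacement does not keep the level of compound 2. Methoxy in place of methyl on a carbonyl carbon gives no change at the digits printed from compound 1 to compound 3 (within the scatter), and with the amide hydrogen present in both compounds, this exchange at the carbonyl carbon leaves the number where it was. Read beside a 10-fold lower number from compound 1 to compound 2 (1.00 log units; beyond the scatter), these steps tie the difference among the three compounds to the methyl on the nitrogen rather than to methoxy against methyl on the carbonyl carbon, though nothing measured here explains either result.

Going by these compounds alone, it remains open whether a methyl on the nitrogen of the (methoxycarbonyl)amino group would lower the number as it does with the acetyl group, since the exchange at the carbonyl carbon has been seen only with the amide hydrogen in place. Also open, on these data alone, is how larger groups on that nitrogen, such as ethyl, or other carbonyl partners, such as ethoxy or dimethylamino, would read in this assay on the same core.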